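Swapping Methyl for Trifluoromethoxy: What Clearance to Expect

The source may hold more compounds than are shown below. What is called first, only, known or untested is meant among the compounds shown, and "the series" means these compounds.

Compound 1 `Cc1cccc(Nc2cc(C3CC3)c(C(=O)NCC3CCOCC3)cn2)c1` shares its core with compound 2 `COc1cccc(Nc2cc(C3CC3)c(C(=O)NCC3CCOCC3)cn2)c1` and compound 3 `O=C(NCC1CCOCC1)c1cnc(Nc2cccc(Br)c2)cc1C1CC1`; the three differ only in the group carried on the six-membered aromatic ring of carbon only. In an in vitro ADME assay on microsomes from liver (Homo sapiens) for metabolic stability (a lower number here means slower removal, a higher number faster removal of the compound), compound 1 gives "not determined" (no result reported), and compound 2 gives "not determined" (no result reported). Compound 3 in this assay gives < 0.5 mL.min-1.g-1, which is a limit of the assay rather than a number. Among the compounds with values here, that is the only reading in this set, and it is the one described in the limit of < 0.5 mL.min-1.g-1 in this assay, at which 1 of the 3 values shown sits. So compound 1 stands without a number of its own, alongside one limit and one further empty entry.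

Compound 4 `O=C(NCC1CCOCC1)c1cnc(Nc2cccc(OC(F)(F)F)c2)cc1C1CC1` differs from compound 1 in one place (trifluoromethoxy in place of methyl on an aromatic carbon). Within the data shown here, no measured pair in this set differs in just that way, so the size of the step cannot be read from the data. Among the measured compounds shown here, the expectation for compound 4 in this assay is a low result, no further from compound 1 than the usual scatter would allow, since the only measured member of the set, compound 3, sat at the limit described in the limit of < 0.5 mL.min-1.g-1 in this assay, at which 1 of the 3 values shown sits. Compound 4 is estimated at 0.7 mL.min-1.g-1, within a range from 0.3 mL.min-1.g-1 to 2 mL.min-1.g-1.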

Compound 4, intrinsic clearance in microsomes: 1 mL.min-1.g-1
For compound 4 the middle estimate is 1.4-fold (0.15 log units) below the measured one; low and high end bracket the measured number.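

In this assay, within the data shown here, compound 4 gives 1 mL.min-1.g-1, the first true number in this small set, so this position on the aromatic ring can carry trifluoromethoxy and still yield a reading that can be quantified. Putting trifluoromethoxy in place of bromo gives an at least 2.0-fold higher number from compound 3 to compound 4 (0.30 log units; that floor lies within the scatter), and since that figure is only a floor, the data fix neither the real size of the step nor whether it exceeds the usual spread between repeat measurements. The reading for compound 3 is a limit of the assay and not a number: the limit of < 0.5 mL.min-1.g-1 in this assay, at which 1 of the 4 values shown sits.

The steps from compound 1 and from compound 2 to compound 4 cannot be read, so the change named in the title, trifluoromethoxy in place of methyl, still has no measured size. Also open is how the same aromatic carbon would behave with a group of a different kind, such as an amine or a carboxylic acid, since the compounds shown carry neither there.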